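Compound 1 and a trifluoromethyl change on its butyl chain

The source may hold more compounds than are shown below. What is called first, only, known or untested is meant among the compounds shown, and "the series" means these compounds.

In a physicochemical assay for solubility, in simulated intestinal fluid, measured as thermodynamic solubility, at pH 6.5 (on this read-out higher numbers stand for higher solubility and lower numbers for lower solubility), compound 1 (`CCCCOc1nc(OCC(C)(C)O)c(-c2ccc(S(C)(=O)=O)cc2)cc1CO`) gives 66500 nM and compound 2 (`CCCCOc1nc(OCC2(O)CCC2)c(-c2ccc(S(C)(=O)=O)cc2)cc1CO`) gives 56100 nM. For the measured compounds named here, compound 1 therefore stands level with the only other measured compound, the gap being a 1.2-fold lower number from compound 1 to compound 2 (0.07 log units; within the scatter).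

Compound 3 (`CC(C)(O)COc1nc(OCCCC(F)(F)F)c(CO)cc1-c1ccc(S(C)(=O)=O)cc1`) differs from compound 1 at another place: trifluoromethyl in place of methyl on a saturated chain carbon, three bonds along the chain from an oxygen on an aromatic ring. Cut one bond further out, this reads butyl to 4,4,4-trifluorobutyl. Going by the values given here, the one measured step replaces 1-hydroxy-1-methylethyl with 1-hydroxycyclobutyl and leaves this chain untouched, so it bears on the change only loosely. Among the compounds with values here, no measured pair shows this change directly, which leaves the expectation uncertain. A modest move to a lower number in this assay is expected, close to the edge of the scatter. The expected step is a 2.1-fold lower number from compound 1 to compound 3 (0.32 log units; beyond the scatter). Compound 3 is estimated at 32000 nM, with a range from 10000 nM to 80000 nM.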

Compound 3, solubility: 111000 nM
The estimate for compound 3 lay 3.5-fold (0.54 log units) below the measured number; measured number above the stated range.
By their numbers in this assay, from the lowest: compounds 2, 1 and 3 (each within the scatter of the next).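

In this assay, the butyl chain of compound 1 now has a measured change of its own: going from butyl to 4,4,4-trifluorobutyl gives a 1.7-fold higher number from compound 1 to compound 3 (0.22 log units; within the scatter). The earlier pair left this chain untouched, and this step shows that trifluoromethyl in place of methyl at this position stays within the usual scatter of repeated measurements. Nothing measured here accounts for where the number falls.

The compounds shown leave open how this position would respond to a group of another kind, such as an amine or a carboxylic acid in place of the trifluoromethyl, or to a longer chain. They also leave open whether the same change on compound 2, with its 1-hydroxycyclobutyl, would give a step of similar size.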